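Benzyloxycarbonyl in place of methyl: a step at the limit

This account rests on a few compounds, and the source may have more. Where it says the series, first, only, none or still open, it means among the compounds named here.

In an ADME assay on HaCaT cells (Homo sapiens) for cytotoxicity, read by MTT assay, with a stated time of 48 h (on this read-out higher numbers stand for weaker inhibition and lower numbers for stronger inhibition), compound 3 (`COc1ccc(-c2nn(-c3ccccc3)cc2-c2nc3cc(C)ccc3[nH]2)cc1`) reaches only a limit, > 50000 nM. Compound 2 (`COc1ccc(-c2nn(-c3ccccc3)cc2-c2nc3cc(Br)ccc3[nH]2)cc1`) also stops at a limit, > 50000 nM. Compound 1 (`O=C(OCc1ccccc1)c1ccc2[nH]c(-c3cn(-c4ccccc4)nc3-c3ccc(Cl)cc3)nc2c1`) likewise gives only a limit, > 50000 nM. No number has yet emerged from this set, and the readings share one ceiling: the limit of > 50000 nM in this assay, at which 3 of the 3 values shown sit.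

Compound 4 (`COc1ccc(-c2nn(-c3ccccc3)cc2-c2nc3cc(C(=O)OCc4ccccc4)ccc3[nH]2)cc1`) changes compound 3 at a single place, on an aromatic carbon of the shared core: benzyloxycarbonyl in place of methyl on an aromatic carbon. Among the compounds with values here, the only measured step with a single change is a step that the two limits leave unreadable from compound 2 to compound 3, methyl in place of bromo on an aromatic carbon, and it offers no size to carry forward. The closest guide is compound 1, which already bears benzyloxycarbonyl and still gives > 50000 nM, a limit. On that basis, no shift beyond the scatter is expected in this assay, and no direction can be assigned. The expected change is a number no higher from compound 3 to compound 4 (the limit leaves the size open). Compound 4 is most likely to return another limit rather than a number. For compound 4 the estimated value is 50000 nM, with an expected range from 25000 nM to 100000 nM.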

Compound 4, half-maximal inhibitory concentration: > 50000 nM
Compound 4 gave a limit, no number; the forecaster's own chance of this, stated with the estimate: 85%; the middle value sits exactly at the limit.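

In this assay compound 4 gives > 50000 nM, a limit and not a number, so its steps to compound 1, compound 2 and compound 3 cannot be read. The compounds shown leave open what size of change, if any, these substitutions produce, as all of the readings share one ceiling: the limit of > 50000 nM in this assay, at which 4 of the 4 values shown sit.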